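Amide and thioamide triazole series: aryl swap notes

The source may hold more compounds than are shown below. What is called first, only, known or untested is meant among the compounds shown, and "the series" means these compounds.

Measured compounds:
- compound 1 `Cc1ccc(NC(=O)CCCn2cc(-c3ccc(C(F)(F)F)cc3)nn2)cc1`: 2300 nM
- compound 2 `O=C(CCCn1cc(-c2ccc(C(F)(F)F)cc2)nn1)Nc1ccc(-c2ccccc2)cc1`: 2000 nM
- compound 3 `COC(=O)c1ccc(-c2cn(CCCC(=S)Nc3ccc(C)cc3)nn2)cc1`: limit only

In a functional assay on MDA-MB-231 cells (Homo sapiens) for inhibition, read by MTT assay, with a stated time of 72 h (on this read-out higher numbers stand for weaker inhibition and lower numbers for stronger inhibition), compound 1 gives 2300 nM and compound 2 gives 2000 nM. The change between them is phenyl in place of methyl on an aromatic carbon, and the step of a 1.2-fold lower number from compound 1 to compound 2 (0.06 log units; within the scatter) is within the scatter. For compound 3 in this assay the value > 100000 nM is a limit of the assay, not a number, as noted at the limit of > 100000 nM in this assay, at which 1 of the 3 values shown sits. How the core of compound 3 differs from the core of compound 1 is not broken down here.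

Compound 4 `COC(=O)c1ccc(-c2cn(CCCC(=S)Nc3ccc(-c4ccccc4)cc3)nn2)cc1` is not yet measured. It differs from compound 3 by phenyl in place of methyl on an aromatic carbon, the same change as from compound 1 to compound 2. Since that step a 1.2-fold lower number from compound 1 to compound 2 (0.06 log units; within the scatter) was within the scatter, the step of a number no higher from compound 3 to compound 4 (the limit leaves the size open) is expected to be small too, and compound 4 is expected to remain at or near the limit. The estimate for compound 4 in this assay is 100000 nM, between 30000 nM and 300000 nM.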

Compound 4, half-maximal inhibitory concentration: > 100000 nM
Compound 4 gave a limit, no number; the forecaster's own chance of this, stated with the estimate: 75%; the middle value lies on the limit itself.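

Among the compounds shown here, compound 3 and compound 4 both stand at a limit, not a number, in this assay, so no step between them can be read: the limit of > 100000 nM in this assay, at which 2 of the 4 values shown sit. The compounds shown leave open the size of the phenyl in place of methyl change in this thioamide pair.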